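Four-Membered Ring Urea Replaces Aromatic Amide: Permeability Outlook

A few compounds are considered here, and "the series" means these few. Any claim that something is new, unique, unknown or untested is made for them only; others in the source may bear on it.

Compound 1 `Cn1cc(-c2nc3c(-c4ccc(CNC(=O)c5nc(C(C)(C)C)no5)c(F)c4)ccnc3[nH]2)cn1`: in an ADME assay on Caco-2 cells (Homo sapiens) for permeability, in the apical to basolateral direction (a higher number here means that the compound crosses the layer faster, a lower number that the compound crosses the layer more slowly), compound 1 gives 11 10^-6 cm/s
Compound 2 `CC1CC2(C1)CN(C(=O)NCc1ccc(-c3ccnc4[nH]c(-c5cnn(C)c5)nc34)cc1F)C2`: in this assay compound 2 gives 8 10^-6 cm/s

Among the measured compounds shown here, compound 1 holds the higher of the two numbers so far, though its gap to compound 2 is a 1.4-fold lower number from compound 1 to compound 2 (0.14 log units; within the scatter). The unmeasured compound 3 `Cn1cc(-c2nc3c(-c4ccc(CNC(=O)N5CC(OC(C)(C)C)C5)c(F)c4)ccnc3[nH]2)cn1` differs from compound 1 by a group of 9 heavy atoms (7 carbon, 1 nitrogen, 1 oxygen; one four-membered non-aromatic ring with 1 hetero atom) in place of a group of 9 heavy atoms (6 carbon, 2 nitrogen, 1 oxygen; one five-membered aromatic ring with 3 hetero atoms), on a carbonyl carbon. For the measured compounds named here, the one step that bears on this is the one from compound 1 to compound 2, in which the same aromatic group left the carbonyl carbon and a four-membered non-aromatic ring with 1 hetero atom entered, and that step stayed within the scatter at a 1.4-fold lower number from compound 1 to compound 2 (0.14 log units; within the scatter). On that basis the step to compound 3 is expected to be a 1.2-fold lower number from compound 1 to compound 3 (0.09 log units; within the scatter), with no change beyond the scatter foreseen. Compound 3 is therefore estimated to give 9 10^-6 cm/s in this assay, with a likely range from 5 10^-6 cm/s to 16 10^-6 cm/s.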

Compound 3, apparent permeability: 0.4 10^-6 cm/s
Beside the measured number, compound 3's estimate is 23-fold (1.35 log units) above it, outside the stated range (below it).
By their numbers in this assay, from the lowest: compound 3; then compounds 2 and 1 (each within the scatter of the next).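

In this assay the group on the carbonyl carbon can move the number a long way, which the earlier pair did not show: a four-membered non-aromatic ring with 1 hetero atom entered there in both compound 2 and compound 3, yet only compound 3 fell far short of compound 1 (a 28-fold lower number from compound 1 to compound 3 (1.44 log units; beyond the scatter)). That ring alone therefore does not set the number, since compound 3 also stands well under compound 2 (a 20-fold lower number from compound 2 to compound 3 (1.30 log units; beyond the scatter)), the two differing only in what the ring carries on the carbonyl side. Nothing given here accounts for this drop.

The compounds shown leave open which part of the group in compound 3 goes with the low number. A methoxy group or a fluorine atom on the same four-membered ring would help to separate the ring from its substituent.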